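This account rests on a few compounds, and the source may have more. Where it says the series, first, only, none or still open, it means among the compounds named here.

Series notes, cytotoxicity on macrophages

Measured in an ADME assay on cells (Peritoneal macrophage cell, Mus musculus, strain C57BL/6) for cytotoxicity, read by LDH release (a lower number here means a stronger inhibitor, a higher number a weaker inhibitor), so far:
- compound 1 `Cc1ccc2[nH]c(C(=O)O)c(/C=N\NC(=O)c3ccncc3)c2c1`: 25 ug/mL
- compound 2 `CCOC(=O)c1[nH]c2ccccc2c1/C=N\NC(=O)c1ccncc1`: 16 ug/mL
- compound 3 `O=C(N/N=C\c1c[nH]c2ccccc12)c1cc[n+]([O-])cc1`: 30 ug/mL

Compound 3 stands at the highest of the three numbers in this assay, though its distance to compound 1 and to compound 2 is within the scatter of repeated measurements, so the three cannot be ordered from these figures. No two of the measured compounds differ in one place only, so no single structural step can be read off from them.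

Compound 4 `CCOC(=O)c1[nH]c2ccccc2c1/C=N\NC(=O)c1cc[n+]([O-])cc1` is the next compound. It is compound 3 with ethoxycarbonyl in place of hydrogen on an aromatic carbon. Nothing measured connects this particular change to a result, so the expectation rests on the spread of the three compounds already in hand.

Expected for compound 4 in this assay: a number close to compound 3, with no step beyond the scatter in either direction, that is a 1.4-fold lower number from compound 3 to compound 4 (0.13 log units; within the scatter). The estimate for compound 4 is 22 ug/mL, expected between 11 ug/mL and 45 ug/mL.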

Compound 4, half-maximal inhibitory concentration: 18 ug/mL
For compound 4 the middle estimate is 1.2-fold (0.09 log units) above the measured one; the measured number falls inside the stated range.
By their numbers in this assay, from the lowest: compounds 2, 4, 1 and 3 (each within the scatter of the next).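

In this assay, the series now has single-place comparisons. Ethoxycarbonyl in place of hydrogen on the aromatic carbon next to the ring nitrogen gives a 1.7-fold lower number from compound 3 to compound 4 (0.22 log units; within the scatter), so at this position a group of this size brings no step beyond the scatter. The change on the carbonyl carbon, from the group of compound 2 to the one with an added oxygen in compound 4, gives a 1.1-fold higher number from compound 2 to compound 4 (0.05 log units; within the scatter), which also stays within the scatter, and no supporting measurement ties either step to a cause.

As far as these compounds go, only hydrogen and ethoxycarbonyl are compared at this position, so it remains open how an amine or a hydroxymethyl group there would read. From the compounds shown here alone, it also remains open whether any single change on the shared core produces a step beyond the scatter in this assay.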